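The compounds below may be only part of what the source reports. "The series", "measured", "known", "first", "only" and "open" are said of these compounds alone.

Measured so far:
compound 1, `CCCCCCc1cc2cn(Cc3cn(Cc4ccccc4)nn3)c(=O)nc2o1`: 68700 nM
compound 2, `CCCCCCC#Cc1c(CCCCCC)oc2nc(=O)n(Cc3cn(Cc4ccccc4)nn3)cc12`: 25800 nM
compound 3, `O=c1nc2oc(CCCCl)c(C#CCCCCl)c2cn1Cc1cn(-c2ccc(Cl)cc2)nn1`: 72500 nM

Among these three, compound 2 gives the lowest number in a functional assay on HepG2 cells (Homo sapiens) for antiproliferative activity, read by MTT assay, with a stated time of 72 h (a higher number here means a weaker inhibitor, a lower number a stronger inhibitor), with compound 1 above it by a 2.7-fold lower number from compound 1 to compound 2 (0.43 log units; beyond the scatter) read backwards and compound 3 higher still. Compound 4, `CCCCCCC#Cc1c(CCCCCC)oc2nc(=O)n(Cc3cn(-c4ccc(F)cc4)nn3)cc12`, keeps the whole core of compound 2 and alters one piece: 4-fluorophenyl in place of benzyl on an aromatic nitrogen.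

Going by the values given here, the only measured step, a 2.7-fold lower number from compound 1 to compound 2 (0.43 log units; beyond the scatter), concerns a different place, the oct-1-yn-1-yl chain on the ring carbon, and says nothing about the group on the triazole nitrogen. Compound 3 carries a 4-chlorophenyl there, but it also differs in its chains, so the value of compound 3, 72500 nM, cannot be split into separate causes. The data therefore hold no direct guide for swapping benzyl for 4-fluorophenyl, and the expectation defaults to a change that stays within the scatter: compound 4 is expected to land near compound 2, with the step of a 1.2-fold higher number from compound 2 to compound 4 (0.09 log units; within the scatter) expected to be small. The estimate for compound 4 in this assay is 32000 nM, within a range of 12000 nM to 80000 nM.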

Compound 4, half-maximal inhibitory concentration: > 100000 nM
Compound 4: no number, only a limit (the forecaster's own chance of this, stated with the estimate: 10%); middle value at least 3.1-fold (0.49 log units) away from the limit.
By their numbers in this assay, from the lowest: compound 2; then compounds 1 and 3 (each within the scatter of the next). At a limit, above all of these: compound 4.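

Going by these compounds alone, this is the first direct reading of the group on an aromatic nitrogen of the five-membered aromatic ring. With the core and both chains unchanged, 4-fluorophenyl in place of benzyl in this assay gives an at least 3.8-fold higher number from compound 2 to compound 4 (0.58 log units; beyond the scatter). Within the data shown here, the two groups have the same count of heavy atoms and each carries one six-membered aromatic ring, yet the change is still beyond the scatter, which the earlier compounds could not show, since they differ at a chain or in several places at once. Compound 4 gives only a limit of the assay and not a number, so the true size of the step stays unknown: the limit of > 100000 nM in this assay, at which 1 of the 4 values shown sits.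

The swap removes the carbon that links the aromatic ring to the nitrogen and also adds a fluorine, and only a plain phenyl group or a 4-fluorobenzyl group at this position would tell these two changes apart. Also open, going by these compounds, is whether the same swap would give a step of similar size on compound 1, which has no oct-1-yn-1-yl chain.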